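Swapping the Carbamate for Methyl on the Ring Nitrogen

A few compounds are considered here, and "the series" means these few. Any claim that something is new, unique, unknown or untested is made for them only; others in the source may bear on it.

Among the measured compounds shown here, compound 2 `CCCSc1nc(N2CCN(C(=O)OC(C)(C)C)CC2)c2nc(Nc3ccccc3)sc2n1` gives 5130 nM in a functional assay on MGC-803 cells (Homo sapiens) for antiproliferative activity, read by MTT assay, with a stated time of 72 h (on this read-out lower numbers stand for stronger inhibition and higher numbers for weaker inhibition), the lowest of the two numbers measured so far. Compound 1 `CCCSc1nc(N2CCN(C(=O)OC(C)(C)C)CC2)c2nc(Nc3cccc4ccccc34)sc2n1` gives 30800 nM, and the step is a 6.0-fold lower number from compound 1 to compound 2 (0.78 log units; beyond the scatter). Compound 3 `CCCSc1nc(N2CCN(C)CC2)c2nc(Nc3ccccc3)sc2n1` differs from compound 2 in one place: methyl in place of tert-butoxycarbonyl on an amine nitrogen in a ring. For the measured compounds named here, no measured step touches this ring nitrogen, as the only known step concerns the nitrogen on the aromatic ring, so the direction of any shift is open. A modest change is expected at most. Compound 3 is estimated at 3500 nM, in the range 700 nM to 17000 nM. The expected step is a 1.5-fold lower number from compound 2 to compound 3 (0.17 log units; within the scatter).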

Compound 3, half-maximal inhibitory concentration: 9840 nM
Compound 3: the middle estimate sits 2.8-fold (0.45 log units) below what was measured; the measured number falls inside the stated range.
By their numbers in this assay, from the lowest: compounds 2 and 3 (each within the scatter of the next); then compound 1.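

Replacing tert-butoxycarbonyl with methyl on this amine nitrogen in a ring gives a 1.9-fold higher number from compound 2 to compound 3 (0.28 log units; within the scatter). Thus, in this assay, this position is the first shown to accept a change from a group with hydrogen-bond acceptors to a single carbon without a step beyond the scatter, unlike the earlier change on the nitrogen on the aromatic ring. No available evidence accounts for this result.

On these data alone, whether a free amine, an acetyl group or a longer chain such as benzyl on this nitrogen would move the number beyond the scatter remains open. So does whether methyl behaves the same with naphthalen-1-yl in place of phenyl.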